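From Hydroxyphenyl to Dichlorophenyl in a Growth Inhibition Series

This account rests on a few compounds, and the source may have more. Where it says the series, first, only, none or still open, it means among the compounds named here.

Compound 1 `O=C(Cc1csc2nc(-c3ccc(Br)cc3)cn12)N/N=C/c1ccccc1O`: 3630 nM
Compound 2 `O=C(Cc1csc2nc(-c3ccc(Br)cc3)cn12)N/N=C/c1ccc(O)cc1`: 17800 nM

Among the measured compounds shown here, in a functional assay on KM12 cells (Homo sapiens) for inhibition, read by sulforhodamine B assay, with a stated time of 48 h (on this read-out higher numbers stand for weaker inhibition of growth and lower numbers for stronger inhibition of growth), compound 1 gives 3630 nM, the lowest of the two numbers; compound 2 is its only neighbour, and the step of a 4.9-fold higher number from compound 1 to compound 2 (0.69 log units; beyond the scatter) lies beyond the scatter. Compound 3 `O=C(Cc1csc2nc(-c3ccc(Br)cc3)cn12)N/N=C/c1ccc(Cl)cc1Cl` is still unmeasured and differs from compound 1 in 2,4-dichlorophenyl in place of 2-hydroxyphenyl on a carbon with a double bond to nitrogen. For the measured compounds named here, the one measured step, a 4.9-fold higher number from compound 1 to compound 2 (0.69 log units; beyond the scatter), concerns only where a hydroxyl sits and involves no chlorine, so it offers little guidance beyond showing that this part of the molecule matters. Compound 3 is expected to show a 1.8-fold higher number from compound 1 to compound 3 (0.25 log units; within the scatter), a modest weakening with wide uncertainty. Compound 3 is estimated at 6500 nM, ranging from 1500 nM to 28000 nM.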

Compound 3, concentration for 50% growth inhibition: 38000 nM
Estimate against measurement, compound 3: 5.8-fold (0.77 log units) below, and the stated range ends below it.
By their numbers in this assay, from the lowest: compound 1; then compound 2; then compound 3.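

In this assay the 2,4-dichlorophenyl group gives weaker growth inhibition than either hydroxyphenyl group, with a 10-fold higher number from compound 1 to compound 3 (1.02 log units; beyond the scatter) and a 2.1-fold higher number from compound 2 to compound 3 (0.33 log units; beyond the scatter) both beyond the scatter. Both compounds with a hydroxyl on this ring therefore stand lower than compound 3, which has none, although the gap is much larger from the 2-hydroxyphenyl group. Nothing given here accounts for this loss. Going by these compounds, whether a single chlorine would weaken growth inhibition as the pair does remains open, as does whether a methoxy group or an amine in place of the hydroxyl would retain the level of compound 1.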